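Ceramide Glucosyltransferase Inhibitors: From Trifluoromethylphenyl to Fluoropyridyl

A few compounds are considered here, and "the series" means these few. Any claim that something is new, unique, unknown or untested is made for them only; others in the source may bear on it.

Measured compounds:
compound 1 `COc1cccc(-c2ccc(COCCCCCN3C[C@H](O)[C@@H](O)[C@H](O)[C@H]3CO)cc2)c1` with 150 nM
compound 2 `OC[C@@H]1[C@@H](O)[C@H](O)[C@@H](O)CN1CCCCCOCc1ccc(-c2ccc(C(F)(F)F)cc2)cc1` with 20 nM

In an assay on isolated protein for inhibition of ceramide glucosyltransferase (Homo sapiens) (on this read-out lower numbers stand for stronger inhibition and higher numbers for weaker inhibition), compound 2 gives 20 nM, the lowest of the two numbers; its nearest neighbour is compound 1 with 150 nM. The step from compound 1 to compound 2 was a 7.5-fold lower number from compound 1 to compound 2 (0.88 log units; beyond the scatter), a change on an aromatic carbon.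

Compound 3 `OC[C@@H]1[C@@H](O)[C@H](O)[C@@H](O)CN1CCCCCOCc1ccc(-c2ccnc(F)c2)cc1` has not yet been measured. It differs from compound 2 by 2-fluoropyridin-4-yl in place of 4-(trifluoromethyl)phenyl on an aromatic carbon. For the measured compounds named here, the only measured step that bears on this change is a 7.5-fold lower number from compound 1 to compound 2 (0.88 log units; beyond the scatter), which concerns the same aromatic carbon but a different pair of groups; no measured step shows a pyridine ring at this place. With the trifluoromethyl leaving and a ring with a hetero atom entering, the expected outcome is uncertain, and a step of a 3.0-fold higher number from compound 2 to compound 3 (0.48 log units; beyond the scatter) is estimated. Compound 3 is therefore expected to give about 60 nM, with a range from 20 nM to 200 nM.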

Compound 3, half-maximal inhibitory concentration: 150 nM
Compound 3: middle estimate off by 2.5-fold (0.40 log units), on the low side; measured number inside the range.
By their numbers in this assay, from the lowest: compound 2; then compounds 1 and 3 (each within the scatter of the next).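

In this assay, putting 2-fluoropyridin-4-yl in place of 4-(trifluoromethyl)phenyl gives a 7.5-fold higher number from compound 2 to compound 3 (0.88 log units; beyond the scatter) and shows that this aromatic carbon also responds to a ring with a hetero atom, not only to a change between rings of carbon alone. Against 3-methoxyphenyl, the same group gives no change at the digits printed from compound 1 to compound 3 (within the scatter) so two differently substituted rings sit level here, and among the three compounds only the 4-(trifluoromethyl)phenyl of compound 2 stands apart. No measurement at hand accounts for the difference between compound 2 and compound 3.

The ring nitrogen and the fluorine enter together in compound 3, so the compounds shown do not separate their contributions. A pyridine ring without fluorine or a fluorophenyl ring at this place would be needed to tell them apart.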